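The source may hold more compounds than are shown below. What is called first, only, known or untested is meant among the compounds shown, and "the series" means these compounds.

Compound 1 `O=C1Nc2ccccc2/C1=N/NC(=S)Nc1cccc(Cl)c1`: 1870 nM
Compound 2 `CN(C)c1ccc(NC(=S)N/N=C2\C(=O)Nc3ccccc32)cc1`: 6950 nM

In a functional assay on KB 3-1 cells (Homo sapiens) for cytotoxicity, read by MTT assay, with a stated time of 72 h (a higher number here means a weaker inhibitor, a lower number a stronger inhibitor), compound 2 at 6950 nM stands highest of the two, with a gap beyond the scatter to compound 1. Compound 3 `CC(C)c1ccc(NC(=S)N/N=C2\C(=O)Nc3ccccc32)cc1` has isopropyl in place of dimethylamino on an aromatic carbon, para to a large group (isopropyl in place of dimethylamino on an aromatic carbon). Among the measured compounds shown here, no measured step in one place covers this change. For the measured compounds named here, a modest move to a lower number in this assay is expected, and the only guide is compound 1 at 1870 nM. The expected step is a 2.3-fold lower number from compound 2 to compound 3 (0.36 log units; beyond the scatter). For compound 3 the estimate is 3000 nM, with an expected range from 1000 nM to 8000 nM.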

Compound 3, half-maximal inhibitory concentration: 9110 nM
Compound 3: the middle estimate sits 3.0-fold (0.48 log units) below what was measured, outside the stated range (above it).
By their numbers in this assay, from the lowest: compound 1; then compounds 2 and 3 (each within the scatter of the next).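

In this assay, isopropyl in place of dimethylamino on an aromatic carbon, para to a large group, gives a 1.3-fold higher number from compound 2 to compound 3 (0.12 log units; within the scatter) and so separates neither compound from the other. At this position, losing the nitrogen and the hydrogen-bond acceptor of dimethylamino therefore has no readable effect on this read-out. No measured property bears on this result. Going by these compounds, whether a carboxylic acid, a primary amine or a longer alkyl chain on the same carbon would also stay within the scatter remains open. Among the compounds shown here, compound 1 differs from these compounds in more than one place, so it gives no step for this position.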